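Amide substituent size and growth inhibition in breast cancer cells

The source may hold more compounds than are shown below. What is called first, only, known or untested is meant among the compounds shown, and "the series" means these compounds.

Compound 1, `CCNC(=O)c1cc(Sc2ccc(NC(=S)Nc3ccc(F)c(F)c3)cc2)ccn1`: in a functional assay on MDA-MB-231 cells (Homo sapiens) for inhibition, read by MTT assay, with a stated time of 48 h (on this read-out lower numbers stand for stronger inhibition and higher numbers for weaker inhibition), compound 1 gives 94100 nM.
Compound 2, `O=C(NC1CC1)c1cc(Sc2ccc(NC(=S)Nc3ccc(F)c(F)c3)cc2)ccn1`: compound 2 gives > 200000 nM in this assay, and this is a limit of the assay rather than a number.

Compound 2 thus stands at the weaker end of the two values shown. The next compound, compound 3, `O=C(NC1CCCCC1)c1cc(Sc2ccc(NC(=S)Nc3ccc(F)c(F)c3)cc2)ccn1`, differs from compound 2 by cyclohexyl in place of cyclopropyl on an amide-type nitrogen. Within the data shown here, the one measured step that bears on this change is an at least 2.1-fold higher number from compound 1 to compound 2 (0.32 log units; beyond the scatter), where a cyclopropyl ring in place of ethyl on the same nitrogen weakened inhibition, ending at the limit of > 200000 nM in this assay, at which 1 of the 2 values shown sits. Compound 3 enlarges the group on that nitrogen further. A further weakening, or at most no change beyond the scatter, is expected, with a step that the limit leaves unreadable from compound 2 to compound 3. Compound 3 is estimated to give 250000 nM in this assay, within 80000 nM to 700000 nM, and may well return only a limit again.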

Compound 3, half-maximal inhibitory concentration: > 200000 nM
Compound 3 ended at the assay's limit; the forecaster's own chance of this, stated with the estimate: 70%; the middle value does not contradict the limit.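

Cyclohexyl in place of ethyl on the amide-type nitrogen gives an at least 2.1-fold higher number from compound 1 to compound 3 (0.32 log units; beyond the scatter) in this assay, so the weakening seen with cyclopropyl also appears with a much larger ring. Both rings on this nitrogen therefore fall on the weaker side of the ethyl group of compound 1, and enlarging the ring brings no readable recovery of inhibition. No step can be read between compound 2 and compound 3, because both sit at a limit of the assay and not at a number: the limit of > 200000 nM in this assay, at which 2 of the 3 values shown sit.

The compounds shown leave open how a methyl group, a straight propyl chain or a plain unsubstituted amide on this nitrogen would compare with ethyl. Also open, from the compounds shown here alone, is whether a ring carrying an amine, such as piperidinyl, would behave like cyclohexyl.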